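This account rests on a few compounds, and the source may have more. Where it says the series, first, only, none or still open, it means among the compounds named here.

Measured compounds:
- compound 1, `O=C1C(Cc2n[nH]c3cc(F)ccc23)C(=O)N(c2ccccc2)C=CN1CC(=O)N1CCCCc2ccccc21`: 1.59 nM
- compound 2, `COc1ccc(N(C(=O)CN2C=CN(c3ccccc3)C(=O)C(Cc3n[nH]c4ccccc34)(OC)C2=O)C(C)C)cc1`: 1380 nM
- compound 3, `O=C1C(Cc2n[nH]c3ccccc23)C(=O)N(c2ccccc2)C=CN1CC(=O)N1CCCCc2ccccc21`: 1.59 nM

All three numbers come from a functional assay on CHO cells for agonist activity at Melanocyte-stimulating hormone receptor (Homo sapiens), read by a luciferase reporter, with a stated time of 4 h; a lower number here means that less compound is needed, a higher number that more compound is needed for the effect. In this assay compound 1 gives 1.59 nM, level with compound 3 at the digits shown, and together these are the lowest two of the three numbers; compound 2, the furthest, gives 1380 nM. Going by the values given here, the only single-point step among the measured compounds is no change at the digits printed from compound 1 to compound 3 (within the scatter), which stays within the scatter and concerns only the fluoro on the aromatic ring.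

Compound 4, `COc1ccc(N(C(=O)CN2C=CN(c3ccccc3)C(=O)C(Cc3n[nH]c4cc(F)ccc34)C2=O)C(C)C)cc1`, keeps the fluoro and the unsubstituted quaternary carbon of compound 1 but carries a different amide: a group of 12 heavy atoms (10 carbon, 1 nitrogen, 1 oxygen; one six-membered aromatic ring of carbon only) in place of a group of 11 heavy atoms (10 carbon, 1 nitrogen; one six-membered aromatic ring of carbon only, one seven-membered non-aromatic ring with 1 hetero atom), on a carbonyl carbon

Among the compounds with values here, no measured step isolates this change. Compound 2 carries the same isopropyl(4-methoxyphenyl)amino amide but also a methoxy on the quaternary carbon and no fluoro, so its value against compound 3 mixes two changes. Taking the fluoro as neutral, the bulk of that gap is assumed to come from the amide exchange, with an unknown share from the methoxy. Compound 4 is therefore expected to lose potency substantially, by an estimated 160-fold higher number from compound 1 to compound 4 (2.20 log units; beyond the scatter), though with wide uncertainty about how much of the compound 2 loss it will carry. For compound 4 the expected value in this assay is 250 nM, range 25 nM to 2500 nM.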

Compound 4, half-maximal effective concentration: 1.59 nM
Estimate against measurement, compound 4: 160-fold (2.20 log units) above; measured number below the stated range.
By their numbers in this assay, from the lowest: compounds 1, 3 and 4 (each within the scatter of the next); then compound 2.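

In this assay, exchanging the group with the seven-membered non-aromatic ring for isopropyl(4-methoxyphenyl)amino, on a carbonyl carbon, gives no change at the digits printed from compound 1 to compound 4 (within the scatter), so this position accepts two quite different amide groups with the rest of compound 1 held constant. The isopropyl(4-methoxyphenyl)amino group therefore cannot by itself account for the high number of compound 2, which gives 1380 nM and also carries a methoxy on the core and no fluoro, so that methoxy and the absent fluoro are the structural differences left to examine. No measurement here gives a reason for this tolerance.

Still open, going by these compounds, is whether the methoxy accounts for the high number of compound 2, since the effect of the fluoro has been read only with the seven-membered ring amide and no single step here isolates either change with the isopropyl(4-methoxyphenyl)amino group. Also open, on these data alone, is how far the tolerance at the carbonyl carbon extends, for example to a small dimethylamino group or a morpholine, and whether a methyl or a hydroxyl on the core would behave as the methoxy does.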